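A few compounds are considered here, and "the series" means these few. Any claim that something is new, unique, unknown or untested is made for them only; others in the source may bear on it.

Measured so far in a functional assay on NB-4 cells (Homo sapiens) for inhibition, read by XTT assay, with a stated time of 48 h; a higher number here means a weaker inhibitor, a lower number a stronger inhibitor:
Compound 1 `COc1ccc(C(=O)/C(=C/c2ccc(Cl)cc2Cl)CCOC(C)=O)cc1` gives 34800 nM.
Compound 2 `CCC(/C=C(\CCOC(C)=O)C(=O)c1ccc(OC)cc1)CC` gives 91100 nM.
For compound 3 `COc1ccc(C(=O)/C(=C/c2ccc([N+](=O)[O-])cc2)CCOC(C)=O)cc1` only a limit is reported, > 100000 nM.

Compound 3 therefore stands at the floor of the numbers shown, at the limit of > 100000 nM in this assay, at which 1 of the 3 values shown sits, without a measured value of its own. Compound 4 `COc1ccc(C(=O)/C(=C/c2ccccc2Cl)CCOC(C)=O)cc1` differs from it by a single change, (2-chlorophenyl in place of 4-nitrophenyl on a double-bonded chain carbon bound to a double-bonded chain carbon). The nearest measured step is an at least 2.8-fold higher number from compound 1 to compound 3 (0.45 log units; beyond the scatter), where a dichlorinated phenyl was exchanged for the same nitrophenyl; the reverse direction, back to a chlorinated phenyl, is what compound 4 represents, so a lower number is expected, though compound 4 carries one chlorine rather than two. Compound 4 is expected to come out at 50000 nM, between 20000 nM and 150000 nM, which means an estimated step of an at least 2.0-fold lower number from compound 3 to compound 4 (0.30 log units; that floor lies within the scatter).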

Compound 4, half-maximal inhibitory concentration: 51600 nM
Compound 4: the middle estimate sits 1.0-fold (0.01 log units) below what was measured; low and high end bracket the measured number.
By their numbers in this assay, from the lowest: compounds 1, 4 and 2 (each within the scatter of the next, the first and the last beyond it). At a limit, above all of these: compound 3.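

In this assay, hydrogen in place of chloro on an aromatic carbon gives a 1.5-fold higher number from compound 1 to compound 4 (0.17 log units; within the scatter) and so shows no clear effect of removing one chlorine. 2-Chlorophenyl in place of pentan-3-yl gives a 1.8-fold lower number from compound 2 to compound 4 (0.25 log units; within the scatter) and does not separate these two groups. 2-Chlorophenyl in place of 4-nitrophenyl gives an at least 1.9-fold lower number from compound 3 to compound 4 (0.28 log units; that floor lies within the scatter) as a floor only, since the value for compound 3 is a limit and not a number.

Open, on these data alone, is how an amine or a carboxylic acid at this place would read in this assay when set against the chlorinated phenyl groups.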